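From dichlorophenyl to nitrophenyl on the ring amine nitrogen

A few compounds are considered here, and "the series" means these few. Any claim that something is new, unique, unknown or untested is made for them only; others in the source may bear on it.

Compound 2 `Nc1scc(CN2CCN(c3cc(Cl)cc(Cl)c3)CC2)c1C(=O)c1ccc(Cl)cc1` gives -74% in a functional assay on CHO cells with adenosine receptor A1 (Homo sapiens) as the target, read by cAMP accumulation and immunoassay, with a stated time of 6 min, tested at 10 uM; on this read-out higher numbers stand for a weaker effect at the one concentration tested and lower numbers for a stronger effect. Compound 1 `Nc1scc(CN2CCN(c3ccc(Cl)cc3Cl)CC2)c1C(=O)c1ccc(Cl)cc1` gives -74%, and the step of no change at the digits printed from compound 1 to compound 2 (within the scatter) shows that exchanging one dichlorophenyl for the other left the read-out unchanged. Compound 3 `Nc1scc(CN2CCN(c3ccc([N+](=O)[O-])cc3)CC2)c1C(=O)c1ccc(Cl)cc1` differs from compound 2 by 4-nitrophenyl in place of 3,5-dichlorophenyl on an amine nitrogen in a ring. Going by the values given here, no measured step exchanges chlorines for a nitro group, so the only guide is that the one change made at this position stayed within the scatter. For compound 3 the expected step is a number 6 percentage points higher from compound 2 to compound 3 (within the scatter), essentially no change beyond the scatter. Compound 3 is estimated at -68%, with a range from -90% to -30%.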

Compound 3, a percentage reported as activity, at one concentration (the size of the read-out at that concentration, not a potency): -17%
Beside the measured number, compound 3's estimate is 51 percentage points below it; the whole stated range lies below it.
By their numbers in this assay, from the lowest: compounds 1 and 2 (each within the scatter of the next); then compound 3.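

In this assay this position proves sensitive to which group sits on the ring amine nitrogen: 4-nitrophenyl gives a number 57 percentage points higher from compound 2 to compound 3 (beyond the scatter) and also a number 57 percentage points higher from compound 1 to compound 3 (beyond the scatter), a clearly weaker effect, whereas the two dichlorophenyl groups stood level. Nothing measured here explains this loss.

Two chlorines leave and a nitro group enters in a single step, so the compounds shown cannot separate the effect of losing the chlorines from that of adding the nitro group. A 4-chlorophenyl or plain phenyl group on the same nitrogen would bear on that question.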